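Methoxy to methyl on two cores, judged by Vero cell viability

The source may hold more compounds than are shown below. What is called first, only, known or untested is meant among the compounds shown, and "the series" means these compounds.

Measured so far:
- compound 1, `COC(=O)[C@H](CO)NC(=O)/C=C/c1ccc(OC)cc1`, gives 103%
- compound 2, `COC(=O)[C@H](CO)NC(=O)/C=C/c1ccc(C)cc1`, gives 101%
- compound 3, `COC(=O)[C@@H]1COC(/C=C/c2ccc(OC)cc2)=N1`, gives 20.9%

All three numbers come from an ADME assay on Vero cells (Chlorocebus sabaeus) for cytotoxicity, read by WST assay, tested at 100 ug/mL; a higher number here means a weaker effect of the compound at the concentration tested, a lower number a stronger effect. Compound 1 and compound 2 share one core and differ only by the change (methyl in place of methoxy on an aromatic carbon). The step of a number 2 percentage points lower from compound 1 to compound 2 (within the scatter) is within the scatter, so the two values of compound 1 and compound 2 are best read as the same.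

Compound 3 stands on a different core; the difference between the two cores is not broken down here. Its value in this assay is the lowest of the three, and its distance to compound 2 and to compound 1 lies beyond the scatter in both cases.

The unmeasured compound 4, `COC(=O)[C@@H]1COC(/C=C/c2ccc(C)cc2)=N1`, is made from compound 3 by methyl in place of methoxy on an aromatic carbon. This is the same change as from compound 1 to compound 2, and the place where it happens is described in the same words for both pairs, so it counts as the same change rather than merely the same kind.

In this assay the step from compound 3 to compound 4 is expected to be a number 1.1 percentage points higher from compound 3 to compound 4 (within the scatter), a step close to the earlier one, because the step of a number 2 percentage points lower from compound 1 to compound 2 (within the scatter) stayed within the scatter. Compound 4 is therefore estimated at 22%, with a likely range from 8% to 45%.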

Compound 4, a percentage reported as activity, at one concentration (the size of the read-out at that concentration, not a potency): 17%
Compound 4: middle estimate off by 5 percentage points, on the high side; low and high end bracket the measured number.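

In this assay, putting methyl in place of methoxy on the core of compound 3 gives a number 3.9 percentage points lower from compound 3 to compound 4 (within the scatter), so here the change leaves no effect that can be told apart from the ordinary spread of repeated measurements. The step seen on the core of compound 1 is much the same, which means that in this small series the change carries from one core to the other without a detectable effect on the reading: the same change on two cores in this assay, a number 2 percentage points lower (within the scatter) from compound 1 to compound 2 and a number 3.9 percentage points lower (within the scatter) from compound 3 to compound 4, 1.9 percentage points apart, within the scatter of two such steps. This does not show that the two groups are interchangeable in general: the comparison rests on just two pairs of compounds, on one assay and on a single concentration, and a small real effect could still be hidden within the scatter.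

The compounds shown have only methoxy or methyl at this place on the aromatic ring, so they leave open what a chlorine atom, a nitrile, an amine or a longer chain would do there. They also leave open how a carboxylic acid in place of the methyl ester would read on either core, and whether the methoxy-to-methyl change would stay this quiet on a third core.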